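Swapping an Ethynyl for a Furan Ring on a Nucleoside

The compounds below may be only part of what the source reports. "The series", "measured", "known", "first", "only" and "open" are said of these compounds alone.

Compound 1 `C#Cc1cn([C@@H]2O[C@H](CO)[C@@H](O)[C@H]2O)c2ncnc(OC)c12` is a sugar-bearing fused two-ring compound carrying an ethynyl group. In a functional assay on K562 cells (Homo sapiens), read by MTT assay, with a stated time of 72 h (a higher number here means a weaker inhibitor, a lower number a stronger inhibitor), compound 1 gives 380 nM. Among the three measured values, this is the only true number, since the other two sit at the limit of > 20000 nM in this assay, at which 2 of the 3 values shown sit. Compound 2 `Cc1ncnc2c1c(-c1cccs1)cn2[C@@H]1O[C@H](CO)[C@@H](O)[C@H]1O` in this assay gives > 20000 nM, which is a limit of the assay rather than a number. Compound 3 `CNc1ncnc2c1c(-c1ccsc1)cn2[C@@H]1O[C@H](CO)[C@@H](O)[C@H]1O` in this assay gives > 20000 nM, again a limit. Compounds 2 and 3 each differ from compound 1 in more than one place, so no single step can be read from them.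

Compound 4 `COc1ncnc2c1c(-c1ccco1)cn2[C@@H]1O[C@H](CO)[C@@H](O)[C@H]1O` has not yet been measured. It differs from compound 1 by furan-2-yl in place of ethynyl on an aromatic carbon. Within the data shown here, no measured pair isolates this change, so the size of the step cannot be read from the data. For compound 4 the expected step is a 3.9-fold higher number from compound 1 to compound 4 (0.60 log units; beyond the scatter), a modest loss in this assay, beyond the scatter but without a reason the data can supply. Compound 4 is therefore estimated at 1500 nM, with a range from 200 nM to 15000 nM.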

Compound 4, half-maximal inhibitory concentration: 380 nM
Beside the measured number, compound 4's estimate is 3.9-fold (0.60 log units) above it; the range from low to high includes it.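

In this assay, replacing ethynyl with furan-2-yl gives no change at the digits printed from compound 1 to compound 4 (within the scatter). Among these compounds, this aromatic carbon of the shared core can therefore carry a five-membered aromatic ring instead of a small group with a triple bond and still give the same reading, something the earlier compounds could not show, as compounds 2 and 3 differ from compounds 1 and 4 in more than one place and no step to them can be read. Nothing measured here explains why the two groups read alike.

This single pair does not show how much else this carbon accepts, so an amine, a carboxylic acid or a longer chain there could read quite differently. It also leaves open whether other aromatic rings at this carbon would match furan-2-yl.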